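The compounds below may be only part of what the source reports. "The series", "measured", "known", "first", "only" and "open" are said of these compounds alone.

Compound 1 `O=C(NCc1ccccc1)c1cncc(Cl)n1` carries a chloro group on its core. In an ADME assay on Vero cells (Chlorocebus sabaeus) for cytotoxicity, read by microscopy, with a stated time of 6 days (a lower number here means that less compound is tolerated, a higher number that more compound is tolerated), compound 1 gives "not determined" (no result reported), so no number stands for it. Two related compounds carry long alkylamino chains instead. Compound 2 `CCCCCCCCNc1cnc(C(=O)NCc2ccccc2)cn1` gives 20000 nM in this assay. Compound 3 `CCCCCCCNc1nccnc1C(=O)NCc1ccccc1` reaches only a limit of this assay, > 100000 nM. Compound 4 `CCCCCCCNc1cncc(C(=O)NCc2ccccc2)n1` differs from compound 1 by heptylamino in place of chloro on an aromatic carbon. Among the measured compounds shown here, since no measured pair differing in one place exists here, the size and direction of the change in this assay cannot be read from the numbers. Because compound 2 gives 20000 nM in this assay, compound 4 is expected near 40000 nM, between 10000 nM and 200000 nM.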

Compound 4, minimum cytotoxic concentration: > 100000 nM
Compound 4: only a limit was reported; the forecaster's own chance of this, stated with the estimate: 40%; middle value at least 2.5-fold (0.39 log units) from the limit.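

Among the compounds shown here, compound 1 has no number in this assay, so no step from it to compound 4 can be read. Compound 4 reaches only a limit, > 100000 nM. The compounds shown leave open how far heptylamino in place of chloro shifts the concentration tolerated.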